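Aryl change at the carbonyl in the ester series

The compounds below may be only part of what the source reports. "The series", "measured", "known", "first", "only" and "open" are said of these compounds alone.

Among the compounds with values here, compound 2 `COc1ccc(C(=O)c2cccc(Cl)c2)cc1OC(=O)CCC(=O)OC[C@@H]1C=C[C@H](n2cc(C)c(=O)[nH]c2=O)O1` gives 6510 nM in a functional assay on HeLa cells (Homo sapiens) for antiproliferative activity, read by MTT assay, with a stated time of 48 h (on this read-out lower numbers stand for stronger inhibition and higher numbers for weaker inhibition), the higher of the two numbers measured so far; compound 1 `COc1cccc(C(=O)c2ccc(OC)c(OC(=O)CCC(=O)OC[C@@H]3C=C[C@H](n4cc(C)c(=O)[nH]c4=O)O3)c2)c1` gives 1580 nM. Within the data shown here, the only measured step, a 4.1-fold higher number from compound 1 to compound 2 (0.61 log units; beyond the scatter), concerns a different exchange on that aryl ring and bears on the next change only loosely. Compound 3 `COc1ccc(C(=O)c2ccc([N+](=O)[O-])cc2)cc1OC(=O)CCC(=O)OC[C@@H]1C=C[C@H](n2cc(C)c(=O)[nH]c2=O)O1` differs from compound 2 by 4-nitrophenyl in place of 3-chlorophenyl on a carbonyl carbon. Among the measured compounds shown here, with a single step of that size as the sole guide, a change no larger than modest is expected in this assay, direction uncertain. Compound 3 is therefore estimated at 5000 nM, between 1800 nM and 14000 nM, corresponding to a 1.3-fold lower number from compound 2 to compound 3 (0.11 log units; within the scatter).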

Compound 3, half-maximal inhibitory concentration: 21100 nM
For compound 3 the middle estimate is 4.2-fold (0.63 log units) below the measured one; measured number outside the range, above it.
By their numbers in this assay, from the lowest: compound 1; then compound 2; then compound 3.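

In this assay the aryl group on the carbonyl carbon clearly matters: 4-nitrophenyl weakens inhibition relative to both 3-chlorophenyl (a 3.2-fold higher number from compound 2 to compound 3 (0.51 log units; beyond the scatter)) and 3-methoxyphenyl (a 13-fold higher number from compound 1 to compound 3 (1.13 log units; beyond the scatter)). The second step is the first large one in the series, and among these three aryl groups 4-nitrophenyl gives the weakest inhibition. Nothing available explains this order.

Going by these compounds, whether the loss follows the nitro group itself or its place on the ring stays open. So does how 3-nitrophenyl or 4-aminophenyl would read at this carbonyl carbon.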